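Carboxyethyl to cyclopropyl amide on the shared core

The source may hold more compounds than are shown below. What is called first, only, known or untested is meant among the compounds shown, and "the series" means these compounds.

In a functional assay on KB cells (Homo sapiens) for inhibition, read by sulforhodamine B assay, with a stated time of 72 h (on this read-out higher numbers stand for weaker inhibition of growth and lower numbers for stronger inhibition of growth), compound 1 (`CN(C)C(=O)/C=C/c1ccncc1-c1ccc2ccccc2c1`) gives 7760 nM. Compound 2 (`O=C(O)CCc1ccncc1-c1ccc2ccccc2c1`) gives only a limit of the assay, > 10000 nM. Going by the values given here, the one measured step bearing here is an at least 1.2-fold higher number from compound 1 to compound 2 (0.11 log units; that floor lies within the scatter), which sets no firm size. Compound 3 (`O=C(/C=C/c1ccncc1-c1ccc2ccccc2c1)NC1CC1`) carries 2-(cyclopropylcarbamoyl)ethenyl in place of 2-carboxyethyl on an aromatic carbon. Its chain is a carbamoyl ethenyl like that of compound 1, so the reverse of an at least 1.2-fold higher number from compound 1 to compound 2 (0.11 log units; that floor lies within the scatter) is the guide. The expected change in this assay is small and toward a lower number: an at least 1.4-fold lower number from compound 2 to compound 3 (0.15 log units; that floor lies within the scatter). For compound 3 the estimate is 7000 nM, ranging from 2500 nM to 14000 nM.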

Compound 3, concentration for 50% growth inhibition: 6050 nM
Estimate against measurement, compound 3: 1.2-fold (0.06 log units) above; measured number inside the range.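

In this assay, cyclopropylamino and dimethylamino on the carbonyl carbon are not told apart: a 1.3-fold lower number from compound 1 to compound 3 (0.11 log units; within the scatter). The other new step gives only a floor, an at least 1.6-fold lower number from compound 2 to compound 3 (0.21 log units; that floor lies within the scatter), and it changes the chain and its end group together. Compound 2 stands at a limit, not a number: the limit of > 10000 nM in this assay, at which 1 of the 3 values shown sits.

Still open, on these data alone, is which part of that change matters, since a 2-carboxyethenyl group or a saturated 2-(cyclopropylcarbamoyl)ethyl chain would separate the double bond from the amide. Also open, as far as these compounds go, is whether a longer chain on the amide nitrogen would give a step beyond the scatter.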